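From methylsulfanyl to ethoxy on a shared core

This account rests on a few compounds, and the source may have more. Where it says the series, first, only, none or still open, it means among the compounds named here.

Measured in a functional assay on HT-29 cells (Homo sapiens) for inhibition, read by sulforhodamine B assay, with a stated time of 72 h; a higher number here means a weaker inhibitor, a lower number a stronger inhibitor:
compound 1 `COc1cc(N2C(=O)CC2c2ccc(SC)cc2)cc(OC)c1OC`: 108 nM
compound 2 `C=CC1C(=O)N(c2cc(OC)c(OC)c(OC)c2)C1c1ccc(SC)cc1`: 113 nM

Among the compounds with values here, compound 1 stands apart from neither number, and the only measured step is a 1.0-fold higher number from compound 1 to compound 2 (0.02 log units; within the scatter). That step, vinyl in place of hydrogen on a saturated ring carbon, lies elsewhere in the molecule. Compound 3 `CCOc1ccc(C2CC(=O)N2c2cc(OC)c(OC)c(OC)c2)cc1` instead carries ethoxy in place of methylsulfanyl on an aromatic carbon. Within the data shown here, no measured step covers this aromatic carbon, so the evidence is indirect and the range stays wide. No change beyond the scatter is expected in this assay, and the expected step is a 1.2-fold higher number from compound 1 to compound 3 (0.08 log units; within the scatter). Compound 3 is estimated at 130 nM, with an expected range of 40 nM to 450 nM.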

Compound 3, half-maximal inhibitory concentration: 65 nM
Estimate against measurement, compound 3: 2.0-fold (0.30 log units) above; measured number inside the range.
By their numbers in this assay, from the lowest: compounds 3, 1 and 2 (each within the scatter of the next).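

In this assay, within the data shown here, ethoxy in place of methylsulfanyl on an aromatic carbon, para to a large group, gives a 1.7-fold lower number from compound 1 to compound 3 (0.22 log units; within the scatter), the first reading at this position. Here, a group joined through oxygen and one carbon longer stands in for the sulfur-linked group with no change beyond the scatter. No measurement given here accounts for this result. The compounds shown leave open how an amine, a carboxylic acid or a longer chain such as butoxy would read on this aromatic carbon. They also leave open whether ethoxy and vinyl together on the shared core would read alike.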